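A few compounds are considered here, and "the series" means these few. Any claim that something is new, unique, unknown or untested is made for them only; others in the source may bear on it.

Three compounds share one core and differ only in one group on the fused ring. Compound 1 `C[C@H](Oc1ccc(S(C)(=O)=O)cc1C(=O)N1Cc2ccccc2C1)C(F)(F)F` carries hydrogen there and gives 2540 nM in an assay on CHO cells for inhibition of sodium- and chloride-dependent glycine transporter 1 (Homo sapiens), read by scintillation counting; a lower number here means that less compound is needed, a higher number that more compound is needed for the effect. Compound 2 `C[C@H](Oc1ccc(S(C)(=O)=O)cc1C(=O)N1Cc2ccc(C(F)(F)F)cc2C1)C(F)(F)F` carries trifluoromethyl and gives 21 nM in this assay. Compound 3 `C[C@H](Oc1ccc(S(C)(=O)=O)cc1C(=O)N1Cc2ccc(N3CCCC3)cc2C1)C(F)(F)F` carries pyrrolidin-1-yl and gives 180 nM in this assay, which places it second of the three, between compound 2 and compound 1. The measured steps show how much this position matters: a 120-fold lower number from compound 1 to compound 2 (2.08 log units; beyond the scatter), a 14-fold lower number from compound 1 to compound 3 (1.15 log units; beyond the scatter), and an 8.6-fold higher number from compound 2 to compound 3 (0.93 log units; beyond the scatter).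

Compound 4 `C[C@H](Oc1ccc(S(C)(=O)=O)cc1C(=O)N1Cc2ccc(N3CCN(C)CC3)cc2C1)C(F)(F)F` continues from compound 3 with 4-methylpiperazin-1-yl in place of pyrrolidin-1-yl on an aromatic carbon. Going by the values given here, of the measured steps, the one from compound 1 to compound 3 bears most closely on this change: it also places a non-aromatic ring with a nitrogen at this position. The step from compound 2 to compound 3 shows that such a ring does not reach the number of trifluoromethyl. Among the compounds with values here, no measured pair compares two rings of this kind with each other, so the expectation rests on compound 3 alone, and only a small shift toward a higher number is expected: a 1.7-fold higher number from compound 3 to compound 4 (0.22 log units; within the scatter). Compound 4 is therefore estimated at 300 nM in this assay, with a range from 100 nM to 1000 nM.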

Compound 4, half-maximal effective concentration: 2080 nM
Compound 4: the middle estimate sits 6.9-fold (0.84 log units) below what was measured; the measured number lies above the stated range.
By their numbers in this assay, from the lowest: compound 2; then compound 3; then compounds 4 and 1 (each within the scatter of the next).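

At this position, the kind of non-aromatic ring with a nitrogen matters a great deal, which compound 3 alone could not reveal: in this assay, the swap of rings gives a 12-fold higher number from compound 3 to compound 4 (1.06 log units; beyond the scatter) and so separates two groups that might have seemed alike. The gain over hydrogen seen with pyrrolidin-1-yl does not carry over to 4-methylpiperazin-1-yl, since a 1.2-fold lower number from compound 1 to compound 4 (0.09 log units; within the scatter) leaves compound 4 level with the compound that has no group here, while a 99-fold higher number from compound 2 to compound 4 (2.00 log units; beyond the scatter) shows how far this ring stands from trifluoromethyl. Nothing available gives a reason for this sharp difference between the two rings.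

The compounds shown leave open which part of the change counts: the six-membered ring, its second nitrogen or the methyl on that nitrogen. Piperidin-1-yl, which has the six-membered ring with only one nitrogen, and piperazin-1-yl, which lacks the methyl, would pull these parts apart, and a small group such as a nitrile would test whether a ring is needed here at all.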